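The source may report more compounds than this note shows. Statements on the series, on what has been measured and on what is new or still open speak of the compounds shown alone.

Compound 1 `CCCCOc1ccc(-c2c(N)nc3ncccn23)cc1` — > 100000 nM
Compound 2 `Nc1nc2ncccn2c1-c1ccc(Br)cc1` — > 100000 nM
Compound 3 `CCCCOc1ccc(-c2nc3ncccn3c2NC2CCCCC2)c(C)c1` — 32000 nM

In a toxicity assay on A549 cells (Homo sapiens) for cytotoxicity, read by luminescence and CellTiter-Glo, with a stated time of 48 h (on this read-out lower numbers stand for higher toxicity in this test and higher numbers for lower toxicity in this test), compound 1 gives > 100000 nM, which is a limit of the assay, not a number. Compound 2 gives > 100000 nM, also a limit. Within the data shown here, compound 3 gives 32000 nM, the only number among the three. The change bromo in place of butoxy on an aromatic carbon produced the step that the two limits leave unreadable from compound 1 to compound 2, whose size cannot be read because of the limit of > 100000 nM in this assay, at which 2 of the 3 values shown sit. How the core of compound 1 and the core of compound 3 differ is not broken down here.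

Compound 4 `Cc1cc(Br)ccc1-c1nc2ncccn2c1NC1CCCCC1` differs from compound 3 by bromo in place of butoxy on an aromatic carbon, the same kind of change, though here the place is meta to a methyl group. With the earlier step unreadable, the expectation rests only on the value of compound 3 and is a step of a 1.3-fold higher number from compound 3 to compound 4 (0.10 log units; within the scatter) in this assay. Compound 4 is therefore estimated at 40000 nM, between 10000 nM and 150000 nM.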

Compound 4, half-maximal cytotoxic concentration: 45000 nM
The estimate for compound 4 lay 1.1-fold (0.05 log units) below the measured number; measured number inside the range.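

In this assay, putting bromo in place of butoxy on the core of compound 3 gives a 1.4-fold higher number from compound 3 to compound 4 (0.15 log units; within the scatter), so on this core the change makes no difference that can be told from ordinary scatter. The same change from compound 1 to compound 2 cannot be read, because each of those two values is a limit of the assay: the limit of > 100000 nM in this assay, at which 2 of the 4 values shown sit. The step on the core of compound 3 therefore stands alone, and nothing here shows whether the change behaves alike on both cores.

The compounds shown leave open whether another group in this place, such as an amine, a carboxylic acid or a longer chain, would give a number clearly apart from that of compound 3 in this assay.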